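A few compounds are considered here, and "the series" means these few. Any claim that something is new, unique, unknown or untested is made for them only; others in the source may bear on it.

Measured compounds in a functional assay on MDA-MB-231 cells (Homo sapiens) for inhibition, read by MTT assay, with a stated time of 72 h; a lower number here means a stronger inhibitor, a higher number a weaker inhibitor:

Compound 1, `O=C(CSc1nc(Nc2ccccc2)c2ccccc2n1)Nc1ccc(Br)cc1`: in this assay compound 1 gives 11500 nM.
Compound 2, `O=C(CSc1nc(Nc2ccccc2)c2ccccc2n1)Nc1ccc(Cl)cc1Cl`: in this assay compound 2 gives 19400 nM.

Compound 2 stands at the highest of the two numbers, and its nearest neighbour is compound 1: a 1.7-fold higher number from compound 1 to compound 2 (0.23 log units; within the scatter). The two values therefore sit within the usual scatter of each other, and nothing can be made of their order.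

Compound 3 is `O=C(CSc1nc(Nc2ccccc2)c2ccccc2n1)Nc1ccc(F)c(Cl)c1`. It keeps the shared core of compound 2 and changes only the ring on the amide-type nitrogen: 3-chloro-4-fluorophenyl in place of 2,4-dichlorophenyl on an amide-type nitrogen.

Among the measured compounds shown here, only one measured step bears on this change. Going from compound 1 to compound 2 also exchanged the ring on the amide-type nitrogen, and that exchange moved the number by an amount within the scatter. With nothing else to go on, a further exchange of this ring is expected to give no step beyond the scatter.

Compound 3 is therefore estimated at 15000 nM in this assay, with a range from 6000 nM to 40000 nM. This estimate means an expected step of a 1.3-fold lower number from compound 2 to compound 3 (0.11 log units; within the scatter).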

Compound 3, half-maximal inhibitory concentration: 21600 nM
Beside the measured number, compound 3's estimate is 1.4-fold (0.16 log units) below it; low and high end bracket the measured number.
By their numbers in this assay, from the lowest: compounds 1, 2 and 3 (each within the scatter of the next).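

In this assay, putting 3-chloro-4-fluorophenyl on the amide-type nitrogen in place of 2,4-dichlorophenyl gives a 1.1-fold higher number from compound 2 to compound 3 (0.05 log units; within the scatter), and putting it there in place of 4-bromophenyl gives a 1.9-fold higher number from compound 1 to compound 3 (0.27 log units; within the scatter), so neither exchange can be read as a real change. Where the earlier compounds offered a single comparison between two rings, there are now three rings at this position, and none of the three pairs can be told apart in this assay, so the position tolerates these particular exchanges without a visible shift in the number. No accompanying evidence offers an explanation for these numbers.

All three rings are phenyl rings carrying halogens, which leaves open whether an unsubstituted phenyl, a phenyl bearing a methoxy group or a carboxylic acid, or a saturated cyclohexyl ring on the same nitrogen would also stay within the scatter. From the compounds shown here alone, it also remains open whether a change away from this nitrogen, such as a longer chain within the shared core or an added amine on it, would move the number beyond the scatter.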